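From benzyloxy to methoxycarbonyl on a carbonyl carbon

The source may report more compounds than this note shows. Statements on the series, on what has been measured and on what is new or still open speak of the compounds shown alone.

In a functional assay on HEL cells (Homo sapiens) (a higher number here means that more compound is tolerated, a lower number that less compound is tolerated), compound 3 `Cc1cn([C@@H]2O[C@H](CO[Si](C)(C)C(C)(C)C)[C@@]3(OS(=O)(=O)C=C3NCC(=O)OCc3ccccc3)[C@H]2O[Si](C)(C)C(C)(C)C)c(=O)n(C)c1=O` gives > 200000 nM as its reading. That reading is a limit of the assay and not a number. Compound 1 `COC(=O)CNC1=CS(=O)(=O)O[C@@]12[C@@H](CO[Si](C)(C)C(C)(C)C)O[C@@H](n1cc(C)c(=O)n(C)c1=O)[C@@H]2O[Si](C)(C)C(C)(C)C` gives 160000 nM in the same test, and compound 2 `Cc1cn([C@@H]2O[C@H](CO[Si](C)(C)C(C)(C)C)[C@@]3(OS(=O)(=O)C=C3NC(N)=O)[C@H]2O[Si](C)(C)C(C)(C)C)c(=O)n(C)c1=O` gives 11000 nM there.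

Compound 4 `COC(=O)C(=O)CNC1=CS(=O)(=O)O[C@@]12[C@@H](CO[Si](C)(C)C(C)(C)C)O[C@@H](n1cc(C)c(=O)n(C)c1=O)[C@@H]2O[Si](C)(C)C(C)(C)C` is still unmeasured. It keeps the shared core of compound 3 but has methoxycarbonyl in place of benzyloxy on a carbonyl carbon, a difference counted as methoxycarbonyl in place of benzyloxy on a carbonyl carbon in full.

Changing only the ester is the closest measured precedent, and it gives an at least 1.2-fold higher number from compound 1 to compound 3 (0.09 log units; that floor lies within the scatter) with no firm change. Changes to the whole group on the amine nitrogen go much further. Putting carbamoyl there gives a 15-fold lower number from compound 1 to compound 2 (1.16 log units; beyond the scatter) as one large step, and replacing carbamoyl with (benzyloxycarbonyl)methyl gives an at least 18-fold higher number from compound 2 to compound 3 (1.25 log units; beyond the scatter) as another.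

Compound 4 has no carbamoyl and keeps an ester-ended chain, as compound 1 does at 160000 nM in that reading. Among the measured compounds shown here, no measured compound carries (methoxycarbonyl)carbonyl, so the range stays wide. Only a modest step towards a lower number is therefore expected in this assay for this change. The expected change is an at least 1.8-fold lower number from compound 3 to compound 4 (0.25 log units; that floor lies within the scatter) on this estimate. For compound 4 the estimated value is 110000 nM with an expected range from 40000 nM to 200000 nM in this test.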

Compound 4, half-maximal cytotoxic concentration: > 200000 nM
Compound 4 gave a limit, no number; the forecaster's own chance of this, stated with the estimate: 30%; middle value at least 1.8-fold (0.25 log units) from the limit.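

In this assay compound 4 gives > 200000 nM, which is a limit of the assay and not a number. Methoxycarbonyl in place of methoxy on a carbonyl carbon gives an at least 1.2-fold higher number from compound 1 to compound 4 (0.09 log units; that floor lies within the scatter), so this longer ester-ended group brings no firm change, while ((methoxycarbonyl)carbonyl)methyl in place of carbamoyl on an amine nitrogen gives an at least 18-fold higher number from compound 2 to compound 4 (1.25 log units; beyond the scatter). Among the compounds shown here, three different ester-ended groups on that nitrogen have now been read, in compound 1, compound 3 and compound 4, and compound 2, with carbamoyl, is the only compound here whose steps to all the others are large and beyond the scatter.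

From the compounds shown here alone, the step between the two compounds that both stop at the limit cannot be read, so any difference between the benzyloxy and methoxycarbonyl ends remains hidden: the limit of > 200000 nM in this assay, at which 2 of the 4 values shown sit. Whether a carboxylic acid or an amine in place of the ester on this chain would give a lower number, as carbamoyl on the nitrogen does, stays open.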